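The source may hold more compounds than are shown below. What is called first, only, known or untested is meant among the compounds shown, and "the series" means these compounds.

In a functional assay on OVCAR-5 cells (Homo sapiens) for inhibition, read by CCK-8 assay, with a stated time of 72 h, tested at 10 uM (on this read-out higher numbers stand for more inhibition of growth at the one concentration tested and lower numbers for less inhibition of growth), three compounds sharing one core have been measured. Compound 1 `CN(C)C(=O)c1cc2cnc(Nc3ccc(NC(=O)C4(C(=O)Nc5ccc(F)cc5)CC4)cc3)nc2n1C1CCCC1` gives 79.7%, compound 2 `CN(C)C(=O)c1cc2cnc(Nc3ccc(NC(=O)C4(C(=O)Nc5ccc(Cl)cc5)CC4)cc3)nc2n1C1CCCC1` gives 85.3%, and compound 3 `CN(C)C(=O)c1cc2cnc(Nc3ccc(NC(=O)C4(C(=O)Nc5cccc(Cl)c5)CC4)cc3)nc2n1C1CCCC1` gives 88.1%. Compound 2 therefore stands within the scatter of both of the others, and these numbers set no order among the three.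

Compound 4 `CN(C)C(=O)c1cc2cnc(Nc3ccc(NC(=O)C4(C(=O)Nc5ccc(Br)cc5)CC4)cc3)nc2n1C1CCCC1` differs from compound 2 in one place: bromo in place of chloro on an aromatic carbon. This is bromo in place of chloro on an aromatic carbon, para to a large group. The nearest guide is the exchange of one halogen for another, chloro in place of fluoro, seen in a number 5.6 percentage points higher from compound 1 to compound 2 (within the scatter). The exchange of 4-chlorophenyl for 3-chlorophenyl, seen in a number 2.8 percentage points higher from compound 2 to compound 3 (within the scatter), bears on it less directly. Within the data shown here, both steps stay within the scatter, and no bromo compound has yet been measured. No change beyond the scatter is therefore expected in this assay. The expected step is small, a number 1.7 percentage points higher from compound 2 to compound 4 (within the scatter). The value of compound 4 is estimated at 87%, with an expected range from 78% to 95%.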

Compound 4, percent growth inhibition at one concentration: 87.8%
Estimate against measurement, compound 4: 0.8 percentage points below; the range from low to high includes it.
By their numbers in this assay, from the lowest: compounds 1, 2, 4 and 3 (each within the scatter of the next).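

With bromo on an aromatic carbon, para to a large group, three halogens have now been compared at this place, and in this assay the exchange of chloro for bromo gives a number 2.5 percentage points higher from compound 2 to compound 4 (within the scatter), while that of fluoro for bromo gives a number 8.1 percentage points higher from compound 1 to compound 4 (within the scatter). The exchange of 3-chlorophenyl for 4-bromophenyl gives a number 0.3 percentage points lower from compound 3 to compound 4 (within the scatter), so this halogen and this ring pattern cannot be told apart on these numbers, and the position accepts all these halogen changes without a step beyond the scatter. Nothing available explains these numbers.

On these data alone, what an amine, a methoxy group or a carboxylic acid would do at this place remains open. Also open, as far as these compounds go, is whether these four halogen compounds would separate at a concentration lower than the one used here.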